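Amide substituent changes on the shared core

A few compounds are considered here, and "the series" means these few. Any claim that something is new, unique, unknown or untested is made for them only; others in the source may bear on it.

Measured compounds:
- Compound 1, `CCOC(=O)CN(C)C(=O)c1ccc(C(CC)(CC)c2ccc(OCC(O)C(C)(C)C)c(C)c2)n1CC`: in a functional assay on HepG2 cells (Homo sapiens), read by MTT assay, with a stated time of 48 h (a lower number here means a stronger inhibitor, a higher number a weaker inhibitor), compound 1 is reported only as the assay limit > 50000 nM.
- Compound 2, `CCn1c(C(=O)NCCN(C)C)ccc1C(CC)(CC)c1ccc(OCC(O)C(C)(C)C)c(C)c1`: in this assay compound 2 gives 870 nM.
- Compound 3, `CCn1c(C(=O)NCC(OC)OC)ccc1C(CC)(CC)c1ccc(OCC(O)C(C)(C)C)c(C)c1`: in this assay compound 3 gives 23200 nM.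

Compound 2 has the lowest of the two numbers in this assay; compound 3 is nearest, and the step of a 27-fold higher number from compound 2 to compound 3 (1.43 log units; beyond the scatter) is large. The third value, for compound 1, is a limit, as noted in the limit of > 50000 nM in this assay, at which 1 of the 3 values shown sits.

Compound 4, `CCn1c(C(=O)N(CCC#N)CCC#N)ccc1C(CC)(CC)c1ccc(OCC(O)C(C)(C)C)c(C)c1`, has not been measured. It differs from compound 2 as a group of 9 heavy atoms (6 carbon, 3 nitrogen; no ring) in place of a group of 6 heavy atoms (4 carbon, 2 nitrogen; no ring), on a carbonyl carbon.

Among the compounds with values here, two measured steps bear on this change. Going from the tertiary amide of compound 1 to compound 2, an at least 57-fold lower number from compound 1 to compound 2 (1.75 log units; beyond the scatter), and replacing the dimethylaminomethyl end of the side chain in compound 2 by a dimethoxymethyl end, a 27-fold higher number from compound 2 to compound 3 (1.43 log units; beyond the scatter). Both steps point the same way: the (2-(dimethylamino)ethyl)amino group goes with the low number, and every variant seen so far without it sits far higher. Compound 4 drops that group entirely and returns to a tertiary amide, as in compound 1. A large rise is therefore expected, with a real chance that only a limit is reported.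

For compound 4 the expected value in this assay is 20000 nM, estimated between 4000 nM and 80000 nM, which is the expected step of a 23-fold higher number from compound 2 to compound 4 (1.36 log units; beyond the scatter).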

Compound 4, half-maximal inhibitory concentration: 42000 nM
Beside the measured number, compound 4's estimate is 2.1-fold (0.32 log units) below it, within the range that was stated.
By their numbers in this assay, from the lowest: compound 2; then compounds 3 and 4 (each within the scatter of the next). At a limit, above all of these: compound 1.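

In this assay, the group of 9 heavy atoms with 2 triple bonds on the carbonyl carbon gives a 48-fold higher number from compound 2 to compound 4 (1.68 log units; beyond the scatter), so a tertiary amide without the (2-(dimethylamino)ethyl)amino group can still give a measured number here, though one far from that of compound 2. The amide hydrogen alone does not separate the two remaining measured values: the step of a 1.8-fold higher number from compound 3 to compound 4 (0.26 log units; within the scatter) goes from a secondary amide to a tertiary amide. The step of an at least 1.1-fold lower number from compound 1 to compound 4 (0.07 log units; that floor lies within the scatter) is only a floor and cannot be read as a size. Compound 1 is reported only as a limit: the limit of > 50000 nM in this assay, at which 1 of the 4 values shown sits.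

Among the compounds shown, only compound 2 carries a dimethylamino end, so these data cannot separate the effect of that end from the effect of the full (2-(dimethylamino)ethyl)amino group. Still open, as far as these compounds go, are how the number responds to a pyrrolidine or morpholine end, a longer chain such as 3-(dimethylamino)propylamino, or an N-methyl tertiary amide that keeps the dimethylamino end.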